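The compounds below may be only part of what the source reports. "The series", "measured", "known", "first", "only" and "open" are said of these compounds alone.

Measured so far:
compound 1 `CCOC(=O)CCO/N=C(/c1ccc(OC)c(OC)c1OC)c1cccc2ccccc12`: 10000 nM
compound 2 `COc1ccc(C(c2ccc(OC(C)CN(C)C)cc2)c2cccc3ccccc23)c(OC)c1OC`: 8410 nM
compound 3 `COc1ccc(C(O)(Cc2ccc(C)cc2)c2cccc3ccccc23)c(OC)c1OC`: > 20000 nM

In a functional assay on HCT-116 cells (Homo sapiens) for inhibition, read by sulforhodamine B assay, with a stated time of 48 h (on this read-out higher numbers stand for weaker inhibition and lower numbers for stronger inhibition), compound 2 gives 8410 nM, the lowest of the two numbers shown. Compound 1 gives 10000 nM, which lies within the scatter of that, so the two cannot be told apart. For compound 3 the assay reports only a limit, > 20000 nM. One of the three results is thus (the limit of > 20000 nM in this assay, at which 1 of the 3 values shown sits).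

Compound 4 `COc1ccc(C(c2ccc(OCC(=O)O)cc2)c2cccc3ccccc23)c(OC)c1OC` differs from compound 2 in one place: carboxymethyl in place of 1-((dimethylamino)methyl)ethyl on an oxygen on an aromatic ring. Going by the values given here, no measured pair shows this kind of swap, so the direction rests on expectation alone. The step expected here, a 1.8-fold higher number from compound 2 to compound 4 (0.25 log units; within the scatter), points toward weaker inhibition, beyond the scatter. Compound 4 is therefore expected to come out near 15000 nM, between 5000 nM and 40000 nM, with a real chance that this assay again returns only a limit.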

Compound 4, half-maximal inhibitory concentration: 5020 nM
The estimate for compound 4 lay 3.0-fold (0.48 log units) above the measured number, within the range that was stated.
By their numbers in this assay, from the lowest: compounds 4, 2 and 1 (each within the scatter of the next). At a limit, above all of these: compound 3.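

Replacing 1-((dimethylamino)methyl)ethyl with carboxymethyl on this oxygen in this assay gives a 1.7-fold lower number from compound 2 to compound 4 (0.22 log units; within the scatter) and so leaves the two compounds indistinguishable. This position therefore carries either a nitrogen-bearing chain or a carboxylic acid chain with no readable difference, although the two groups share little beyond their attachment through the oxygen. Nothing shown bears on what lies behind this result.

As far as these compounds go, whether a bare hydroxyl, a methyl ether, an amide or a longer carboxylic acid chain on this oxygen would read differently remains open. So does whether any other group here would move the number beyond the scatter.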